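Swapping the ring system at the double bond

The source may hold more compounds than are shown below. What is called first, only, known or untested is meant among the compounds shown, and "the series" means these compounds.

Compound 1 `O=C(O)/C=C/c1ccc(/C(=C(\c2ccccc2)C2CCC2)c2ccc3[nH]ncc3c2)cc1`: 1.4 nM
Compound 2 `CC/C(=C(/c1ccc(/C=C/C(=O)O)cc1)c1cnc2[nH]ncc2c1)c1ccccc1`: 302 nM

In a functional assay on MCF7 cells (Homo sapiens) for cytotoxicity, read by CellTiter-Glo, with a stated time of 5 days (a lower number here means a stronger inhibitor, a higher number a weaker inhibitor), compound 2 gives the highest of the two numbers, far from compound 1. Compound 3 `CC/C(=C(/c1ccc(/C=C/C(=O)O)cc1)c1ccc2[nH]ncc2c1Cl)c1ccccc1` changes compound 2 in one place: a group of 10 heavy atoms (7 carbon, 2 nitrogen, 1 chlorine; one five-membered aromatic ring with 2 hetero atoms, one six-membered aromatic ring of carbon only) in place of a group of 9 heavy atoms (6 carbon, 3 nitrogen; one five-membered aromatic ring with 2 hetero atoms, one six-membered aromatic ring with 1 hetero atom), on a double-bonded chain carbon bound to an aromatic carbon and a double-bonded chain carbon. Among the measured compounds shown here, no measured pair shows this change, so the expected step from compound 2 to compound 3, a 25-fold lower number from compound 2 to compound 3 (1.40 log units; beyond the scatter), is a guess toward a lower number, beyond the scatter, because compound 1 with a similarly fused carbon-only six-membered ring gives 1.4 nM. Compound 3 is estimated at 12 nM, within 2 nM to 70 nM.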

Compound 3, half-maximal inhibitory concentration: 1.6 nM
Compound 3: the middle estimate sits 7.5-fold (0.88 log units) above what was measured, and the stated range ends above it.
By their numbers in this assay, from the lowest: compounds 1 and 3 (each within the scatter of the next); then compound 2.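

In this assay the group on this double-bonded chain carbon matters greatly: a 190-fold lower number from compound 2 to compound 3 (2.28 log units; beyond the scatter) comes with 4-chloro-1H-indazol-5-yl entering. This single change removes a ring nitrogen and adds a chlorine together, so the step cannot be divided between those two parts.

As far as these compounds go, it remains open how the number would move if a fluorine atom or a methyl group took the place of the chlorine in compound 3. Nothing measured here gives a reason for the size of this step.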